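Series notes: aryl variation on the acylthiourea and cytotoxicity

The compounds below may be only part of what the source reports. "The series", "measured", "known", "first", "only" and "open" are said of these compounds alone.

Measured so far, in an ADME assay on Huh-7 cells (Homo sapiens) for cytotoxicity; on this read-out lower numbers stand for higher toxicity in this test and higher numbers for lower toxicity in this test:
compound 1 `O=C(NC(=S)N1CCc2c(OCCCCCOc3ccc(Cl)cc3)cccc21)c1cccc([N+](=O)[O-])c1`: 12100 nM
compound 2 `N#Cc1cccc(C(=O)NC(=S)N2CCc3c(OCCCCCOc4ccc(Cl)cc4)cccc32)c1`: 9750 nM
compound 3 `COc1ccc(C(=O)NC(=S)N2CCc3c(OCCCCCOc4ccc(Cl)cc4)cccc32)cc1`: 34400 nM

Compound 3 gives the highest number of the three in this assay, that is the least toxicity seen so far. The steps that reach it are a 2.8-fold higher number from compound 1 to compound 3 (0.45 log units; beyond the scatter) and a 3.5-fold higher number from compound 2 to compound 3 (0.55 log units; beyond the scatter), both modest and both beyond the scatter. Between compound 1 and compound 2 the step is a 1.2-fold lower number from compound 1 to compound 2 (0.09 log units; within the scatter), so the nitro and cyano analogues cannot be told apart.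

Compound 4 `CN(C)c1ccc(C(=O)NC(=S)N2CCc3c(OCCCCCOc4ccc(Cl)cc4)cccc32)cc1` differs from compound 3 by dimethylamino in place of methoxy on an aromatic carbon. Within the data shown here, no measured step changes this position on its own: the two steps that lead to compound 3 each exchange the whole aryl group, a meta-substituted ring for the 4-methoxyphenyl, and neither compares one para substituent against another. The only ground for an expectation is therefore that compound 4 keeps the 4-substituted arrangement of compound 3, whose value 34400 nM is the starting point.

With nothing in the measured steps pointing either way, a step within the scatter is expected, a 1.1-fold lower number from compound 3 to compound 4 (0.06 log units; within the scatter). Compound 4 is accordingly estimated at 30000 nM in this assay, with a range from 12000 nM to 80000 nM; the wide range reflects that the measured compounds give no direct guide to this change.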

Compound 4, half-maximal cytotoxic concentration: > 50000 nM
Compound 4: no number, only a limit; the forecaster's own chance of this, stated with the estimate: 15%; middle value at least 1.6-fold (0.22 log units) from the limit.
By their numbers in this assay, from the lowest: compounds 2 and 1 (each within the scatter of the next); then compound 3. At a limit, above all of these: compound 4.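

For compound 4, this assay gives a limit and not a number: the limit of > 50000 nM in this assay, at which 1 of the 4 values shown sits.

Among these compounds, this is the first comparison of two substituents on the same aromatic carbon, and dimethylamino in place of methoxy gives an at least 1.4-fold higher number from compound 3 to compound 4 (0.16 log units; that floor lies within the scatter), so compound 4 cannot be placed beyond the scatter of compound 3, though the change shows no drop in the number at this position. Against the two aryl groups that carry nitro and cyano, the 4-(dimethylamino)phenyl group gives an at least 5.1-fold higher number from compound 2 to compound 4 (0.70 log units; beyond the scatter) and an at least 4.1-fold higher number from compound 1 to compound 4 (0.61 log units; beyond the scatter), so among these four compounds both 4-substituted phenyl groups, 4-methoxyphenyl and 4-(dimethylamino)phenyl, stand clear of compound 1 and compound 2, with no compound shown going against this.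

The compounds shown leave open how far compound 4 lies past its limit, and whether the higher numbers follow the place of the substituent or the substituent itself, as no substituent appears at both ring places. Also open, on these data alone, is how a primary amine or a carboxylic acid on this same aromatic carbon would read in this assay.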